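Adding Fluoromethyl to the Cyclohexyl Group of Compound 3

This account rests on a few compounds, and the source may have more. Where it says the series, first, only, none or still open, it means among the compounds named here.

Measured compounds:
- compound 1 `CC1CC=C(C(=O)N(c2cc(C#CC(C)(C)C)sc2C(=O)O)C(C)C)CC1`: 0.08
- compound 2 `CC(C)(C)C#Cc1cc(N(C(=O)[C@H]2CC[C@H](C)CC2)[C@H]2CC[C@H](Oc3cccnc3)CC2)c(C(=O)O)s1`: 0.03
- compound 3 `CC(C)N(C(=O)C1CCCCC1)c1cc(C#CC(C)(C)C)sc1C(=O)O`: 0.18

In an ADME assay for protein binding, using equilibrium dialysis, at pH 7.4, tested at 2 uM (a lower number here means a smaller unbound share, a higher number a larger unbound share of the compound), compound 3 stands highest of the three, at 0.18. Compound 4 `CC(C)N(c1cc(C#CC(C)(C)C)sc1C(=O)O)C(=O)[C@H]1CC[C@H](CF)CC1`, not yet measured, differs from it in one place: fluoromethyl in place of hydrogen on a saturated ring carbon. Cyclohexyl thus becomes 4-(fluoromethyl)cyclohexyl. Within the data shown here, the only measured step that bears on this is a 2.3-fold higher number from compound 1 to compound 3 (0.35 log units; beyond the scatter), where 4-methylcyclohex-1-en-1-yl gave way to cyclohexyl. It is a partial guide, since neither group in it holds fluoromethyl. Read in reverse, it suggests that a modest fall is to be expected. The expected step is a 1.6-fold lower number from compound 3 to compound 4 (0.21 log units; within the scatter). Compound 4 is estimated at 0.11, with an expected range from 0.06 to 0.19.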

Compound 4, unbound fraction: 0.18
Estimate against measurement, compound 4: 1.6-fold (0.21 log units) below, within the range that was stated.
By their numbers in this assay, from the lowest: compound 2; then compound 1; then compounds 3 and 4 (each within the scatter of the next).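

In this assay, fluoromethyl on the saturated ring carbon gives no change at the digits printed from compound 3 to compound 4 (within the scatter), so this position, three ring bonds from the ring atom that bears a large group, takes the added carbon and fluorine without a step beyond the scatter. Replacing 4-methylcyclohex-1-en-1-yl with 4-(fluoromethyl)cyclohexyl gives a 2.3-fold higher number from compound 1 to compound 4 (0.35 log units; beyond the scatter), which matches a 2.3-fold higher number from compound 1 to compound 3 (0.35 log units; beyond the scatter) for plain cyclohexyl. Nothing at hand gives a reason for this result.

Still open, on these data alone, is whether an amine, a hydroxymethyl group or a longer chain on this ring carbon would read the same. A single fluoromethyl example also cannot show how far this tolerance extends.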